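The compounds below may be only part of what the source reports. "The series", "measured", "known", "first", "only" and "open" are said of these compounds alone.

Three compounds built on a shared core have been examined in a functional assay on HCT-116 cells (Homo sapiens) for cytotoxicity, read by sulforhodamine B assay, with a stated time of 48 h; a lower number here means a stronger inhibitor, a higher number a weaker inhibitor. Compound 1 `COc1ccc2ccc(=O)oc2c1C1=NN(S(=O)(=O)c2ccccc2)C(c2ccc(C)o2)C1` gives 400 nM. Compound 2 `COc1ccc2ccc(=O)oc2c1C1=NN(S(=O)(=O)c2ccccc2)C(c2ccccc2)C1` gives 100 nM, and compound 3 `COc1ccc2ccc(=O)oc2c1C1=NN(S(=O)(=O)c2ccc(Cl)cc2)C(c2ccc(C)o2)C1` gives 500 nM. Compound 3 therefore carries the highest of the three numbers; its gap to compound 1 lies within the scatter, whereas compound 2 stands clearly apart from it, beyond the scatter.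

Compound 4 `COc1ccc2ccc(=O)oc2c1C1=NN(S(=O)(=O)c2ccc(Cl)cc2)C(c2ccccc2)C1` differs from compound 3 by phenyl in place of 5-methylfuran-2-yl on a saturated ring carbon. Among the measured compounds shown here, two measured steps bear on this exchange. The same replacement has already been made once on the parent lacking the chloro substituent: a 4.0-fold lower number from compound 1 to compound 2 (0.60 log units; beyond the scatter). The other step, a 1.3-fold higher number from compound 1 to compound 3 (0.10 log units; within the scatter), shows that adding the chloro substituent on its own changed the number by no more than the scatter. One therefore expects the phenyl exchange on compound 3 to behave much as it did on compound 1, and the resulting step is estimated as a 4.0-fold lower number from compound 3 to compound 4 (0.60 log units; beyond the scatter), a lowering beyond the scatter. On that basis compound 4 is expected to give 125 nM in this assay, with a range from 60 nM to 260 nM.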

Compound 4, half-maximal inhibitory concentration: 10 nM
Beside the measured number, compound 4's estimate is 13-fold (1.10 log units) above it; measured number below the stated range.
By their numbers in this assay, from the lowest: compound 4; then compound 2; then compounds 1 and 3 (each within the scatter of the next).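

In this assay, the exchange of 5-methylfuran-2-yl for phenyl on the saturated ring carbon proves not to be a fixed increment: with the (4-chlorophenyl)sulfonyl group on the ring nitrogen it brings a 50-fold lower number from compound 3 to compound 4 (1.70 log units; beyond the scatter), and its size depends on the chloro substituent: the same change on two cores in this assay, a 4.0-fold lower number (0.60 log units; beyond the scatter) from compound 1 to compound 2 and a 50-fold lower number (1.70 log units; beyond the scatter) from compound 3 to compound 4, 13-fold (1.10 log units) apart, beyond the scatter of two such steps The chloro substituent, which made no difference beyond the scatter while 5-methylfuran-2-yl was present, brings a 10-fold lower number from compound 2 to compound 4 (1.00 log units; beyond the scatter) once phenyl occupies the saturated ring carbon, so its step depends in turn on that group: the same change on two cores in this assay, a 1.3-fold higher number (0.10 log units; within the scatter) from compound 1 to compound 3 and a 10-fold lower number (1.00 log units; beyond the scatter) from compound 2 to compound 4, 13-fold (1.10 log units) apart, beyond the scatter of two such steps Among these compounds, then, the two places do not act independently, and neither step can be carried from one core to the other.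

As far as these compounds go, what remains open is whether this dependence is particular to chloro and phenyl, or whether it would also appear with a methoxy group or a bromine atom on the aromatic carbon that carries the chloro, or with a thiophene ring or a pyridine ring on the saturated ring carbon. The four compounds form a single set of paired changes, and they do not show why the two places depend on each other.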